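Three Measured Analogues and an Unmeasured Carbonyl Variant

A few compounds are considered here, and "the series" means these few. Any claim that something is new, unique, unknown or untested is made for them only; others in the source may bear on it.

Three compounds were tested in a functional assay on UACC-257 cells (Homo sapiens) for inhibition, read by sulforhodamine B assay, with a stated time of 48 h, tested at 0.01 uM; a higher number here means a weaker effect of the compound at the concentration tested, a lower number a stronger effect:

compound 1 `COc1cc(Cl)cc(-c2nn(-c3cccc(NC(=O)Nc4ccc(Cl)c(C(F)(F)F)c4)c3)cc2-c2ccncc2)c1`: 91%
compound 2 `COc1cc(Cl)cc(-c2nn(-c3cccc(NC(=O)Nc4ccc(Cl)c(Cl)c4)c3)cc2-c2ccncc2)c1`: 96%
compound 3 `COc1cc(Cl)cc(-c2nn(-c3cccc(NC(=O)Nc4cccc(C(F)(F)F)c4)c3)cc2-c2ccncc2)c1`: 90%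

Compound 3 gives the lowest of the three numbers, yet the step of a number 1 percentage points lower from compound 1 to compound 3 (within the scatter) and the step of a number 6 percentage points lower from compound 2 to compound 3 (within the scatter) both lie within the scatter, as does a number 5 percentage points higher from compound 1 to compound 2 (within the scatter). Compound 4 `COc1cc(Cl)cc(-c2nn(-c3cccc(NC(=O)c4cccc(C(F)(F)F)c4)c3)cc2-c2ccncc2)c1` differs from compound 3 by 3-(trifluoromethyl)phenyl in place of (3-(trifluoromethyl)phenyl)amino on a carbonyl carbon. Among the measured compounds shown here, none of the measured steps touches this carbonyl carbon; all three concern the distal aromatic ring and were within the scatter. The data therefore give no ground for a step beyond the scatter, so compound 4 is expected to show a number 1 percentage points higher from compound 3 to compound 4 (within the scatter) in this assay. The estimate for compound 4 is 91%, with a range from 76% to 104%.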

Compound 4, a percentage reported as activity, at one concentration (the size of the read-out at that concentration, not a potency): 91%
For compound 4 middle estimate and measured number coincide at the digits printed, and the stated range covers the measured number.
By their numbers in this assay, from the lowest: compounds 3, 1, 4 and 2 (each within the scatter of the next).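

In this assay, the change at the carbonyl carbon itself, which removes the hydrogen-bond donor of the leaving (3-(trifluoromethyl)phenyl)amino group, gives a number 1 percentage points higher from compound 3 to compound 4 (within the scatter). The wider comparisons agree, with a number 5 percentage points lower from compound 2 to compound 4 (within the scatter) and no change at the digits printed from compound 1 to compound 4 (within the scatter), so the loss of this nitrogen leaves the read-out within the scatter at the concentration tested. Nothing measured here accounts for this result.

As far as these compounds go, whether a methylene group or an oxygen atom in that nitrogen's place would read the same remains open. With only one concentration shown, whether these compounds would differ in the size of their effect at any other concentration also remains open.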